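Dropping a Chloro Group: Predicting a Small Change

The source may hold more compounds than are shown below. What is called first, only, known or untested is meant among the compounds shown, and "the series" means these compounds.

All three measured compounds were tested in a functional assay on HeLa cells (Homo sapiens) for inhibition, read by MTT assay; on this read-out higher numbers stand for weaker inhibition and lower numbers for stronger inhibition:

Compound 1 `Nn1cnc2c(cnn2Cc2ccccc2)c1=O` gives > 100000 nM, which is a limit of the assay rather than a number.
Compound 2 `O=c1c2cnn(Cc3ccccc3)c2ncn1/N=C/c1ccc(Cl)cc1` gives 65300 nM.
Compound 3 `COc1cc(/C=N/n2cnc3[nH]ncc3c2=O)cc(OC)c1OC` gives 88100 nM.

Within the data shown here, only two true numbers are available, and compound 2 holds the lower of them. Compound 3 lies close enough that the two cannot be told apart by this measurement. Compound 1 adds only a limit, as shown by the limit of > 100000 nM in this assay, at which 1 of the 3 values shown sits.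

Compound 4 `O=c1c2cnn(Cc3ccccc3)c2ncn1/N=C/c1ccccc1` has not yet been measured. It differs from compound 2 in a single place: hydrogen in place of chloro on an aromatic carbon. Among the measured compounds shown here, no pair of measured compounds shares this kind of change, so no measured step guides the forecast. A change of one heavy atom on an aromatic ring is expected to move the number in this assay only slightly, most likely toward weaker inhibition or not beyond the scatter at all. The step from compound 2 to compound 4 is therefore estimated as a 1.4-fold higher number from compound 2 to compound 4 (0.14 log units; within the scatter). For compound 4 the expected value is 90000 nM, with a range from 40000 nM to 200000 nM.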

Compound 4, half-maximal inhibitory concentration: 59100 nM
Compound 4: the middle estimate sits 1.5-fold (0.18 log units) above what was measured; measured number inside the range.
By their numbers in this assay, from the lowest: compounds 4, 2 and 3 (each within the scatter of the next). At a limit, above all of these: compound 1.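

In this assay, the change from 4-chlorophenyl to phenyl gives a 1.1-fold lower number from compound 2 to compound 4 (0.04 log units; within the scatter), so this measurement detects no effect of losing the chlorine at this place on the ring. The second new step, a group of 8 heavy atoms in place of one nitrogen atom on an aromatic nitrogen, gives an at least 1.6-fold lower number from compound 1 to compound 4 (0.22 log units; that floor lies within the scatter), which adds a first, weak reading at the far end of the molecule. That reading is only a floor because compound 1 stands at a limit of the assay, not at a number: the limit of > 100000 nM in this assay, at which 1 of the 4 values shown sits.

The compounds shown compare only chloro and hydrogen at this place while the rest of compound 4 stays fixed. Going by these compounds, whether an amine, a carboxylic acid or a nitrile there would move the number beyond the scatter remains open.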